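Removing a Methyl from a Phenol Ether: What to Expect

The compounds below may be only part of what the source reports. "The series", "measured", "known", "first", "only" and "open" are said of these compounds alone.

Of the compounds shown here, three with a shared core have been tested in a functional assay on UACC-257 cells (Homo sapiens) for inhibition, read by sulforhodamine B assay, with a stated time of 48 h; a lower number here means that less compound is tolerated, a higher number that more compound is tolerated. Compound 2 `COc1cc(-c2nn(-c3cccc(NC(=O)Nc4ccc(Cl)c(C(F)(F)F)c4)c3)cc2-c2ccncc2)ccc1Cl` is the only one that yields an actual number there, giving 29200 nM. Compound 1 `COc1cc(-c2nn(-c3cccc(NC(=O)c4ccc(Cl)c(C(F)(F)F)c4)c3)cc2-c2ccncc2)ccc1Cl` reaches only a limit of the assay, recorded as > 32500 nM. Compound 3 `COc1cc(-c2nn(-c3cccc(NC(=O)c4ccccc4)c3)cc2-c2ccncc2)ccc1Cl` likewise gives only a limit, recorded as > 100000 nM. For the measured compounds named here, all the measured steps alter the group on the carbonyl carbon: there is an at least 1.1-fold lower number from compound 1 to compound 2 (0.04 log units; that floor lies within the scatter), there is an at least 3.4-fold higher number from compound 2 to compound 3 (0.53 log units; beyond the scatter), and there is a step that the two limits leave unreadable from compound 1 to compound 3.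

Compound 4 `O=C(Nc1cccc(-n2cc(-c3ccncc3)c(-c3ccc(Cl)c(O)c3)n2)c1)Nc1ccc(Cl)c(C(F)(F)F)c1` differs from compound 2 at a different place altogether: hydrogen in place of methyl on an oxygen on an aromatic ring. Going by the values given here, none of the measured steps touches this oxygen, so they offer no guidance on how large such a change might be or in which direction it might point. With nothing in the data pointing either way, the change in this assay is expected to stay within the usual scatter of repeated measurements. Compound 4 is therefore estimated at 30000 nM, with a range from 12000 nM to 75000 nM, which corresponds to an expected step of a 1.0-fold higher number from compound 2 to compound 4 (0.01 log units; within the scatter). Given that compound 1 sits at a limit, the assay might again report only a limit rather than a number.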

Compound 4, concentration lethal to 50% of the cells: 8390 nM
For compound 4 the middle estimate is 3.6-fold (0.55 log units) above the measured one; measured number outside the range, below it.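

In this assay, the oxygen on the aromatic ring turns out to be a place where a very small edit registers: hydroxy in place of methoxy gives a 3.5-fold lower number from compound 2 to compound 4 (0.54 log units; beyond the scatter), so less compound is tolerated once the methyl is gone. For the compounds shown here, every earlier step changed the group on the carbonyl carbon, so this is the first sign that the 4-chloro-3-methoxyphenyl part of the molecule also affects the read-out. The change removes only a single carbon as its one heavy atom, yet the step lies beyond the scatter, although it is modest in size.

Nothing shown here bears on what lies behind this step. As far as these compounds go, it remains open whether an ethyl group or a longer chain on this oxygen, or an amine in place of the hydroxy, would move the number further, and whether the same methyl-to-hydrogen change would have a similar effect with the carbonyl groups of compound 1 or compound 3.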